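Swapping the pyridine for a piperidine on the biaryl core

The source may report more compounds than this note shows. Statements on the series, on what has been measured and on what is new or still open speak of the compounds shown alone.

Measured so far:
Compound 1 `COc1ccccc1C(=O)NC(=O)Nc1ccc(-c2ccccc2)c(C(C)C)c1` gives < 1 ug/mL in a physicochemical assay for solubility, in phosphate buffer, at pH 7.4; on this read-out higher numbers stand for higher solubility and lower numbers for lower solubility; this is a limit of the assay rather than a number.
Compound 2 `COc1ccccc1C(=O)NC(=O)Nc1ccc(-c2ccccn2)c(C(F)(F)F)c1` gives 19 ug/mL in this assay.

For the measured compounds named here, compound 2 therefore stands as the only compound with an actual number in this assay. Going by the values given here, the other value belongs to compound 1 and sits at the limit of < 1 ug/mL in this assay, at which 1 of the 2 values shown sits, so no measured step between the two compounds can be stated, only that compound 2 has a readable value where compound 1 does not.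

Compound 3 `COc1ccccc1C(=O)NC(=O)Nc1ccc(N2CCCCC2)c(C(F)(F)F)c1` differs from compound 2 in one place: piperidin-1-yl in place of pyridin-2-yl on an aromatic carbon. The shared core with its methoxybenzoyl urea and the trifluoromethyl group stays unchanged.

Among the compounds with values here, no measured step of this kind is available, so the expectation rests only on the structural change itself. The step from compound 2 to compound 3 in this assay is expected to be a 1.6-fold higher number from compound 2 to compound 3 (0.20 log units; within the scatter), a modest rise that may not exceed the usual scatter. Compound 3 is therefore estimated at 30 ug/mL, with a plausible range from 8 ug/mL to 120 ug/mL.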

Compound 3, solubility: < 1 ug/mL
Compound 3: a limit, no number (the forecaster's own chance of this, stated with the estimate: 10%); middle value at least 30-fold (1.47 log units) away from the limit.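

For the compounds shown here, this is the first step that can be read in this assay: placing piperidin-1-yl instead of pyridin-2-yl on the aromatic carbon ortho to a trifluoromethyl group gives an at least 19-fold lower number from compound 2 to compound 3 (1.27 log units; beyond the scatter). The two groups have the same counts of heavy atoms, hydrogen-bond donors and hydrogen-bond acceptors, and each is a six-membered ring with one nitrogen, so at this position those counts alone do not tell how the compound will read out. Compound 3 gives < 1 ug/mL, which is a limit of the assay and not a number, so the full size of the step stays unknown: the limit of < 1 ug/mL in this assay, at which 2 of the 3 values shown sit.

The compounds shown leave open whether the fall follows the loss of the aromatic ring or the change from a ring joined through carbon to one joined through nitrogen. A cyclohexyl ring on the same carbon would keep the non-aromatic ring but join through carbon, and a morpholin-4-yl ring would keep the join through nitrogen while adding an oxygen to the ring.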